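The compounds below may be only part of what the source reports. "The series", "measured", "known", "first", "only" and "open" are said of these compounds alone.

Compound 1 `C=C/C=C\[C@H](C)[C@H](OC(N)=O)[C@@H](C)[C@H](O)[C@@H](C)C/C(C)=C\[C@H](C)[C@@H](O)[C@@H](C)/C=C\CCc1ccsc1` is the thiophen-3-yl member of the series. In a functional assay on MCF7 cells (Homo sapiens) for cytotoxicity (a lower number here means a stronger inhibitor, a higher number a weaker inhibitor), compound 1 gives 850 nM, the highest number among the three measured compounds. Compound 2 `C=C/C=C\[C@H](C)[C@H](OC(N)=O)[C@@H](C)[C@H](O)[C@@H](C)C/C(C)=C\[C@H](C)[C@@H](O)[C@@H](C)/C=C\CCc1cccc(OC)c1` gives 330 nM in this assay, and compound 3 `C=C/C=C\[C@H](C)[C@H](OC(N)=O)[C@@H](C)[C@H](O)[C@@H](C)C/C(C)=C\[C@H](C)[C@@H](O)[C@@H](C)/C=C\CCc1cccc(F)c1` gives 370 nM. Both measured steps away from compound 1 exchange thiophen-3-yl for a six-membered carbon ring at the same place on the chain: a 2.6-fold lower number from compound 1 to compound 2 (0.41 log units; beyond the scatter), and a 2.3-fold lower number from compound 1 to compound 3 (0.36 log units; beyond the scatter). The two phenyl compounds sit together, a 1.1-fold higher number from compound 2 to compound 3 (0.05 log units; within the scatter).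

Compound 4 `C=C/C=C\[C@H](C)[C@H](OC(N)=O)[C@@H](C)[C@H](O)[C@@H](C)C/C(C)=C\[C@H](C)[C@@H](O)[C@@H](C)/C=C\CCc1cc(O)cc(O)c1` carries the change (3,5-dihydroxyphenyl in place of thiophen-3-yl on a saturated chain carbon, two bonds along the chain from a double-bonded chain carbon). The steps to compound 2 and compound 3 bear on it, since each also replaces thiophen-3-yl with a six-membered ring of carbon only at this position, and each was a modest lowering beyond the scatter. Among the measured compounds shown here, no measured step tests hydroxy groups on that ring, so the size for compound 4 is uncertain. For compound 4 a modest lowering is expected, a 1.9-fold lower number from compound 1 to compound 4 (0.28 log units; within the scatter). Compound 4 is therefore estimated at about 450 nM in this assay, within 150 nM to 1400 nM.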

Compound 4, half-maximal inhibitory concentration: 160 nM
Estimate against measurement, compound 4: 2.8-fold (0.45 log units) above; low and high end bracket the measured number.
By their numbers in this assay, from the lowest: compound 4; then compounds 2 and 3 (each within the scatter of the next); then compound 1.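

In this assay the ring substituents now matter: 3,5-dihydroxyphenyl gives a 2.3-fold lower number from compound 3 to compound 4 (0.36 log units; beyond the scatter) against 3-fluorophenyl and a 2.1-fold lower number from compound 2 to compound 4 (0.31 log units; beyond the scatter) against 3-methoxyphenyl, both beyond the scatter, whereas the fluoro and methoxy compounds alone showed no separation. The full exchange of thiophen-3-yl at this saturated chain carbon now reaches a 5.3-fold lower number from compound 1 to compound 4 (0.73 log units; beyond the scatter) and remains a modest step, so this position accepts a ring with hydroxy groups without loss in this assay. Nothing available explains why the dihydroxy ring gives the lowest number of the series.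

From the compounds shown here alone, whether one hydroxy group would suffice, or whether an amine or a carboxylic acid on the same ring would behave similarly, stays open. Also open, going by these compounds, is how a longer chain between the double bond and the 3,5-dihydroxyphenyl ring would read.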